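A Ring Swap at the Low End of the Series

The source may report more compounds than this note shows. Statements on the series, on what has been measured and on what is new or still open speak of the compounds shown alone.

compound 1 `O=C(Nc1ccccc1)c1cnc(NCc2c(F)ccc3c2CCO3)n2cnnc12` gives 4.1
compound 2 `CN(c1ccccc1)c1cnc(NCc2c(F)ccc3c2CCO3)n2cnnc12` gives 3.6
compound 3 `CN(c1ccn(C)n1)c1cnc(NCc2c(F)ccc3c2CCO3)n2cnnc12` gives 1.8

Within the data shown here, in a physicochemical assay for lipophilicity, using the shake flask method, in phosphate buffer, measured as octanol-water partition, with a stated time of 30 min, at pH 7.4 (on this read-out higher numbers stand for higher lipophilicity and lower numbers for lower lipophilicity), compound 3 stands lowest of the three at 1.8 on the numbers so far. Compound 4 `C[C@H]1CC(=O)N(c2cnc(NCc3c(F)ccc4c3CCO4)n3cnnc23)C1` has not yet been measured. It carries 4-methyl-2-oxopyrrolidin-1-yl in place of methyl(1-methyl-1H-pyrazol-3-yl)amino on an aromatic carbon and is otherwise the same as compound 3. Among the measured compounds shown here, no measured step brings in the entering group, so the evidence is indirect. Exchanges on this same aromatic carbon gave a number 0.50 log units lower from compound 1 to compound 2 (beyond the scatter) and a number 2.30 log units lower from compound 1 to compound 3 (beyond the scatter) in the series, while swapping only the ring on the nitrogen gave a number 1.80 log units lower from compound 2 to compound 3 (beyond the scatter) on the same scale. Changes here have therefore moved the number by modest to large amounts. With compound 3 at the bottom at 1.8 and both other values well higher, a modest upward move is expected, with a number 0.60 log units higher from compound 3 to compound 4 (beyond the scatter) as the estimated step. The estimate for compound 4 is 2.4 and the expected range runs from 1.9 to 2.9 on this measurement.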

Compound 4, distribution coefficient: 1.8
For compound 4 the middle estimate is 0.60 log units above the measured one; the whole stated range lies above it.
By their numbers in this assay, from the lowest: compounds 3 and 4 (each within the scatter of the next); then compound 2; then compound 1.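

In this assay, the exchange of methyl(1-methyl-1H-pyrazol-3-yl)amino for 4-methyl-2-oxopyrrolidin-1-yl gives no change at the digits printed from compound 3 to compound 4 (within the scatter), so on this aromatic carbon a five-membered non-aromatic ring matches a group carrying a five-membered aromatic ring, despite their different counts of hydrogen-bond acceptors. Putting the same entering group in place of methyl(phenyl)amino gives a number 1.80 log units lower from compound 2 to compound 4 (beyond the scatter), and putting it in place of phenylcarbamoyl gives a number 2.30 log units lower from compound 1 to compound 4 (beyond the scatter). The low end of this small series is therefore no longer held by the pyrazole-bearing group alone.

From the compounds shown here alone, whether the same reading would hold for the parent 2-oxopyrrolidin-1-yl ring without its methyl, for the opposite stereocentre or for a morpholine on this carbon remains open. Nothing given here accounts for the two groups reading alike.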